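The compounds below may be only part of what the source reports. "The series", "measured", "known", "first", "only" and "open" are said of these compounds alone.

Measured so far in a functional assay on A-375 cells (Homo sapiens) for antiproliferative activity, read by MTT assay, with a stated time of 24 h; on this read-out higher numbers stand for weaker inhibition and lower numbers for stronger inhibition:
- compound 1 `C=CCOc1ccc2c(=O)c(-c3cc(OC)c(OC)cc3OC)coc2c1`: 4750 nM
- compound 2 `COc1cc(OC)c(-c2coc3cc(OCc4ccccc4C)ccc3c2=O)cc1OC`: 1360 nM

Of these two, compound 2 has the lower number, 1360 nM, and so the stronger inhibition in this assay. The next compound, compound 3 `COc1cc(OC)c(-c2coc3cc(OCc4ccc([N+](=O)[O-])cc4)ccc3c2=O)cc1OC`, changes only the group on the saturated chain carbon bound to an oxygen on an aromatic ring: 4-nitrophenyl in place of 2-methylphenyl on a saturated chain carbon bound to an oxygen on an aromatic ring. In short, 4-nitrophenyl stands in place of 2-methylphenyl.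

Going by the values given here, one measured step bears on this place: a 3.5-fold lower number from compound 1 to compound 2 (0.54 log units; beyond the scatter). That modest step replaced vinyl with 2-methylphenyl, so it compares a compound without an aromatic ring at this place with one that has it. Compound 3 keeps a six-membered aromatic ring there, and only the groups on that ring differ. Among the compounds with values here, no measured compound shows what such a difference does, so no direction can be supported. The expected step is small, probably within the scatter: a 1.1-fold higher number from compound 2 to compound 3 (0.04 log units; within the scatter). For compound 3 the estimate is 1500 nM, with an expected range of 500 nM to 4500 nM.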

Compound 3, half-maximal inhibitory concentration: > 10000 nM
Compound 3 gave a limit, no number; the forecaster's own chance of this, stated with the estimate: 3%; at least 6.6-fold (0.82 log units) between middle value and limit.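

In this assay compound 3 gives > 10000 nM, which is a limit of the assay and not a number: the limit of > 10000 nM in this assay, at which 1 of the 3 values shown sits. Keeping a six-membered aromatic ring at this place does not preserve the activity, as 4-nitrophenyl in place of 2-methylphenyl gives an at least 7.3-fold higher number from compound 2 to compound 3 (0.86 log units; beyond the scatter), so the groups on that ring matter here, which the earlier pair could not show. The 4-nitrophenyl group also compares unfavourably with vinyl, giving an at least 2.1-fold higher number from compound 1 to compound 3 (0.32 log units; beyond the scatter), so an aromatic ring at this place does not by itself go with the lower number, although the step with 2-methylphenyl ran the other way, a 3.5-fold lower number from compound 1 to compound 2 (0.54 log units; beyond the scatter).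

The two ring-bearing groups shown differ both in the group on the ring and in its numbered place, so the nitro group cannot be separated from that shift; 4-methylphenyl or 2-nitrophenyl would be needed to pull the two apart. Unsubstituted phenyl and a ring carrying an amine or a carboxylic acid also remain open, as does how a longer chain in place of the vinyl group would read.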